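A few compounds are considered here, and "the series" means these few. Any claim that something is new, unique, unknown or untested is made for them only; others in the source may bear on it.

In a cytotoxicity series, compound 1 `CN(C)CCn1c(N)c(-c2nc3ccccc3[nH]2)c2nc(C#N)c(C#N)nc21` gives 9730 nM in an ADME assay on HEK293 cells (Homo sapiens) for cytotoxicity, read by MTT assay, with a stated time of 48 h; a higher number here means a weaker inhibitor, a lower number a stronger inhibitor. Compound 2 `CCN(CC)CCn1c(N)c(-c2nc3ccccc3[nH]2)c2nc(C#N)c(C#N)nc21` differs from it only by diethylamino in place of dimethylamino on a saturated chain carbon, two bonds along the chain from an aromatic nitrogen, and in this assay compound 2 gives 12200 nM, so the step of a 1.3-fold higher number from compound 1 to compound 2 (0.10 log units; within the scatter) is small. Compound 3 `CN(C)CCCCn1c(N)c(-c2nc3ccccc3o2)c2nc(C#N)c(C#N)nc21` has a different core; the difference between the two cores is not broken down here. In this assay compound 3 gives 6240 nM, within the scatter of both compound 1 and compound 2.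

Compound 4 `CCN(CC)CCCCn1c(N)c(-c2nc3ccccc3o2)c2nc(C#N)c(C#N)nc21` is the not-yet-measured partner of compound 3, and it carries diethylamino in place of dimethylamino on a saturated chain carbon, four bonds along the chain from an aromatic nitrogen. Among the compounds with values here, this is the same kind of change as the one from compound 1 to compound 2, though the place is not identical: there the amine sat two bonds along the chain from the aromatic nitrogen, here it sits four bonds along. Because the step of a 1.3-fold higher number from compound 1 to compound 2 (0.10 log units; within the scatter) stayed within the scatter, the step from compound 3 to compound 4 is expected to be about as small, a 1.3-fold higher number from compound 3 to compound 4 (0.11 log units; within the scatter). On that basis compound 4 is estimated to give 8000 nM in this assay, most likely between 4000 nM and 16000 nM.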

Compound 4, half-maximal inhibitory concentration: 3960 nM
Compound 4: the middle estimate sits 2.0-fold (0.31 log units) above what was measured; measured number below the stated range.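

In this assay, diethylamino in place of dimethylamino gives a 1.6-fold lower number from compound 3 to compound 4 (0.20 log units; within the scatter), so on this second core the change again stays inside the usual scatter. Set beside the earlier step, the two cannot be told apart: the same change on two cores in this assay, a 1.3-fold higher number (0.10 log units; within the scatter) from compound 1 to compound 2 and a 1.6-fold lower number (0.20 log units; within the scatter) from compound 3 to compound 4, 2.0-fold (0.30 log units) apart, within the scatter of two such steps. This shows that, in these two pairs, the change carries from one core to the other without a difference that rises above the scatter, but the pairs also differ in the place of the change, two bonds along the chain from the aromatic nitrogen in one and four in the other, and a single pair on each core neither separates core from chain length nor sets a rule for the series.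

The compounds shown leave open how the 3-(diethylamino)propyl chain would read on either core, and how the four-bond chain would read on the core of compound 1. Also open, on these data alone, is how a cyclic amine such as piperidine or morpholine at the chain end would compare in this assay.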